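The source may hold more compounds than are shown below. What is called first, only, known or untested is meant among the compounds shown, and "the series" means these compounds.

Working notes on the series, read in an ADME assay on HEK293 cells (Homo sapiens) for cytotoxicity, read by MTT assay, with a stated time of 72 h; on this read-out lower numbers stand for stronger inhibition and higher numbers for weaker inhibition. Compound 1 `O=C(CN1CCN(C(=O)c2ccc(Cl)cc2)CC1)N1CCN(CCCc2c[nH]c3ccccc23)CC1` gives 98200 nM, compound 2 `O=C(CN1CCN(C(=O)c2cccc(Br)c2)CC1)N1CCN(CCCc2c[nH]c3ccccc23)CC1` gives 80700 nM, and compound 3 `O=C(CN1CCN(C(=O)c2ccc(Cl)cc2)CC1)N1CCN(CCCc2c[nH]c3ccc(F)cc23)CC1` gives 44500 nM. Compound 3 has the smallest number of the three, but its value and that of compound 2 lie within the scatter of each other. Only its separation from compound 1 goes beyond the scatter, as a 2.2-fold lower number from compound 1 to compound 3 (0.34 log units; beyond the scatter) shows, and that step is modest.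

The next analogue is compound 4 `Cc1ccc(C(=O)N2CCN(CC(=O)N3CCN(CCCc4c[nH]c5ccc(F)cc45)CC3)CC2)cc1`, with methyl in place of chloro on an aromatic carbon. The change turns 4-chlorophenyl into 4-methylphenyl.

Within the data shown here, no measured pair makes this exact replacement. Among the measured compounds shown here, the closest evidence is a 1.2-fold lower number from compound 1 to compound 2 (0.09 log units; within the scatter), the only measured change on this aryl group, and it stays within the scatter. The fluoro step, a 2.2-fold lower number from compound 1 to compound 3 (0.34 log units; beyond the scatter), lies elsewhere in the molecule and does not bear directly on this change. No step beyond the scatter is therefore expected in this assay, and no direction can be assigned. The estimate stays close to compound 3 at 44500 nM.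

The expected change is a 1.1-fold higher number from compound 3 to compound 4 (0.03 log units; within the scatter). For compound 4 the estimated value is 48000 nM, with an expected range of 24000 nM to 95000 nM.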

Compound 4, half-maximal inhibitory concentration: 141000 nM
Beside the measured number, compound 4's estimate is 2.9-fold (0.47 log units) below it; measured number outside the range, above it.
By their numbers in this assay, from the lowest: compounds 3, 2, 1 and 4 (each within the scatter of the next, the first and the last beyond it).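

The aryl group on the carbonyl is not a silent position in this assay. Among these compounds, with the fluoro on the core held constant, 4-methylphenyl in place of 4-chlorophenyl gives a 3.2-fold higher number from compound 3 to compound 4 (0.50 log units; beyond the scatter), a modest step, whereas the only earlier change on this aryl group, a 1.2-fold lower number from compound 1 to compound 2 (0.09 log units; within the scatter), stayed within the scatter. Exchanging one heavy atom for another, with no change in ring, hydrogen-bond count or net charge, is therefore enough to shift the read-out towards weaker inhibition, and nothing in the data shown accounts for this step.

The compounds shown leave open whether the step belongs to the arrival of methyl or the departure of chloro, since neither a hydrogen nor another group at this place is paired with compound 3 or compound 4. Also open, as far as these compounds go, is whether the same exchange gives a similar step on the core of compound 1, without the fluoro, and how a methoxy group or an amine at this place would read.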